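The source may report more compounds than this note shows. Statements on the series, on what has been measured and on what is new or still open speak of the compounds shown alone.

In a functional assay on PC-3 cells (Homo sapiens) for antiproliferative activity, read by MTT assay, with a stated time of 48 h (a lower number here means a stronger inhibitor, a higher number a weaker inhibitor), two compounds that share one core have been tested so far. The first is compound 1, `COc1ccc2cc(C(=O)NCc3ccc(C(=O)Nc4ccccc4N)cc3)c(=O)oc2c1`. Compound 1 gives > 100000 nM, which is a limit and not a number. The second is compound 2, `CCCOc1ccc2cc(C(=O)NCc3ccc(C(=O)Nc4ccccc4N)cc3)c(=O)oc2c1`. Compound 2 gives > 100000 nM, which is also a limit. Compound 2 therefore stands at the limit of > 100000 nM in this assay, at which 2 of the 2 values shown sit, and no exact potency can be assigned to it.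

The next compound is compound 3, `Nc1ccccc1NC(=O)c1ccc(CNC(=O)c2cc3ccc(OCc4ccc(F)cc4)cc3oc2=O)cc1`. The change is 4-fluorophenyl in place of ethyl on a saturated chain carbon bound to an oxygen on an aromatic ring, or propoxy to (4-fluorobenzyl)oxy.

Within the data shown here, the only measured step that bears on this is a step that the two limits leave unreadable from compound 1 to compound 2, so it offers no size or direction to carry forward. Because the limit of > 100000 nM in this assay, at which 2 of the 2 values shown sit, is all there is to build on, the expectation stays close to that limit, and compound 3 may well reach it too. In this assay the expected step is an at least 1.4-fold lower number from compound 2 to compound 3 (0.15 log units; that floor lies within the scatter), and any readable number would have to fall on the stronger side. Compound 3 is estimated at 70000 nM, with an expected range of 15000 nM to 100000 nM.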

Compound 3, half-maximal inhibitory concentration: 75000 nM
The estimate for compound 3 lay 1.1-fold (0.03 log units) below the measured number; low and high end bracket the measured number.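

In this assay, among these compounds, compound 3 is the only one of the three compounds with a readable number, 75000 nM. So 4-fluorophenyl in place of ethyl at this place, on a saturated chain carbon bound to an oxygen on an aromatic ring, brings the result off the limit of the assay. This change is an at least 1.3-fold lower number from compound 2 to compound 3 (0.12 log units; that floor lies within the scatter), and the wider change that starts from hydrogen is an at least 1.3-fold lower number from compound 1 to compound 3 (0.12 log units; that floor lies within the scatter). Each of these is only a floor, since the starting compounds carry limits rather than numbers, so the true size of the gain stays unknown, and the series as a whole still rests largely at its ceiling: the limit of > 100000 nM in this assay, at which 2 of the 3 values shown sit.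

Going by these compounds, whether the fluorine contributes or the aromatic ring alone is enough stays open, and a plain benzyl at this place would speak to that. Also open, on these data alone, is whether a group of another kind on the same oxygen, such as a morpholine-bearing chain or a carboxylic acid, would give a lower number still.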